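The source may hold more compounds than are shown below. What is called first, only, known or untested is meant among the compounds shown, and "the series" means these compounds.

Measured so far:
- compound 1, `COc1ccc(C(=O)/C=C/c2ccc(Br)cc2)c2c1C=CC(C)(C)O2`: > 10000 nM
- compound 2, `COc1ccc(C(=O)/C=C/c2ccc3ccccc3n2)c2c1C=CC(C)(C)O2`: 3020 nM
- compound 3, `COc1ccc(C(=O)/C=C/c2cccc3ccccc23)c2c1C=CC(C)(C)O2`: > 10000 nM

All three were run in a functional assay on K562 cells (Homo sapiens) for antiproliferative activity, read by MTT assay, with a stated time of 24 h; a higher number here means a weaker inhibitor, a lower number a stronger inhibitor. Compound 1 gives > 10000 nM, which is a limit of this assay and not a number. Compound 3 likewise gives > 10000 nM, again a limit. For the measured compounds named here, compound 2 is the one measured value, at 3020 nM. Where compound 1 stands is thus known only as a limit, and the limit of > 10000 nM in this assay, at which 2 of the 3 values shown sit, is the one piece of evidence that frames the set. Going by the values given here, no step between two measured compounds is available for this series.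

Compound 4, `COc1ccc(C(=O)/C=C/c2ccccc2Cl)c2c1C=CC(C)(C)O2`, is the next to go into this assay. It differs from compound 1 by 2-chlorophenyl in place of 4-bromophenyl on a double-bonded chain carbon bound to a double-bonded chain carbon. Among the compounds with values here, with no measured step to lean on, the expectation is that compound 4 stays near the limit, with no step beyond the scatter from compound 1: the step that the limit leaves unreadable from compound 1 to compound 4 is expected to be nil or small. Compound 4 is estimated at 12000 nM, with a range from 3000 nM to 40000 nM, and most likely reported again as a limit.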

Compound 4, half-maximal inhibitory concentration: > 10000 nM
Compound 4: a limit, no number; the forecaster's own chance of this, stated with the estimate: 65%; the middle value does not contradict the limit.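

Compound 1 and compound 4 both stand only as limits in this assay, and the step between them cannot be read. The compounds shown leave open whether 2-chlorophenyl in place of 4-bromophenyl changes antiproliferative activity at all, and where either compound's true value lies.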